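This account rests on a few compounds, and the source may have more. Where it says the series, first, only, none or still open, it means among the compounds named here.

In a functional assay on XF498 cells (Homo sapiens) for cytotoxicity (on this read-out lower numbers stand for stronger inhibition and higher numbers for weaker inhibition), compound 1 (`Cc1ccc2c(O)nc(-c3ccccc3C)cc2c1`) gives 1990 nM and compound 2 (`Cc1ccc2c(N3CCN(C)CC3)nc(-c3ccc(Cl)cc3)cc2c1`) gives 4070 nM. Compound 2 therefore holds the higher of the two numbers, and the gap between them lies beyond the usual scatter. These two compounds differ in more than one place, so their gap cannot be assigned to any single change.

Compound 3 (`Cc1ccc2c(N3CCN(C)CC3)nc(-c3ccccc3C)cc2c1`) keeps the 4-methylpiperazin-1-yl group of compound 2 and changes one place: 2-methylphenyl in place of 4-chlorophenyl on an aromatic carbon. In words, 2-methylphenyl stands in place of 4-chlorophenyl on an aromatic carbon, next to the ring nitrogen. Compound 1 also carries the 2-methylphenyl group, but it lacks the 4-methylpiperazin-1-yl group, so it offers only a loose guide.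

For the measured compounds named here, no measured pair shows this swap on its own, which leaves the expectation weakly supported. In this assay, only a small move toward a lower number is expected, with nothing beyond the scatter. The expected change is an estimated step of a 1.4-fold lower number from compound 2 to compound 3 (0.13 log units; within the scatter). For compound 3, the estimated value is 3000 nM, with an expected range of 1000 nM to 9000 nM.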

Compound 3, half-maximal inhibitory concentration: 6610 nM
Estimate against measurement, compound 3: 2.2-fold (0.34 log units) below; low and high end bracket the measured number.
By their numbers in this assay, from the lowest: compound 1; then compounds 2 and 3 (each within the scatter of the next).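

In this assay, 2-methylphenyl in place of 4-chlorophenyl, on the aromatic carbon next to the ring nitrogen, gives a 1.6-fold higher number from compound 2 to compound 3 (0.21 log units; within the scatter) and so stays within the usual scatter. On this pair, then, the two aromatic groups cannot be told apart by this read-out. For the compounds shown here, compound 3 also gives the first comparison that changes only the other substituent: with 2-methylphenyl held constant, 4-methylpiperazin-1-yl in place of hydroxy gives a 3.3-fold higher number from compound 1 to compound 3 (0.52 log units; beyond the scatter) and so, unlike the aromatic swap, moves beyond the scatter, a modest shift toward weaker inhibition. Nothing measured here offers a reason for either step.

Going by these compounds, each step rests on a single pair, so it remains open whether the change from hydroxy to 4-methylpiperazin-1-yl would have a similar size with 4-chlorophenyl on the core. Also open, on these data alone, is how other groups would read in these two places, such as an unsubstituted phenyl at the aromatic position or a simple primary amine where compound 1 carries its hydroxy.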